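Adding a Methoxy Group: Two Parallel Steps

The compounds below may be only part of what the source reports. "The series", "measured", "known", "first", "only" and "open" are said of these compounds alone.

Measured compounds, each with its result in a functional assay on MCF7 cells (Homo sapiens) for cytotoxicity, read by MTT assay, with a stated time of 72 h; on this read-out lower numbers stand for stronger inhibition of growth and higher numbers for weaker inhibition of growth:
compound 1 `COc1ccc(CNc2nc([SeH])nc3ccccc23)cc1` gives 94000 nM.
compound 2 `[SeH]c1nc(NCc2ccccc2)c2ccccc2n1` reaches only the limit of the assay, > 100000 nM.
compound 3 `CSc1nc(NCc2ccccc2)c2ccccc2n1` gives 82800 nM.

Compounds 1 and 2 share one core, and the change from compound 2 to compound 1 is methoxy in place of hydrogen on an aromatic carbon, which gave a step of an at least 1.0-fold lower number from compound 2 to compound 1 (0.02 log units; that floor lies within the scatter). Compound 3 carries the other core; the two cores differ by a group of 2 heavy atoms (1 carbon, 1 sulfur; no ring) in place of one selenium atom, on an aromatic carbon, and that change gave an at least 1.2-fold lower number from compound 2 to compound 3 (0.08 log units; that floor lies within the scatter). Compound 2 sits at the limit of > 100000 nM in this assay, at which 1 of the 3 values shown sits, so both steps from it are floors only.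

Compound 4 `COc1ccc(CNc2nc(SC)nc3ccccc23)cc1` has not yet been measured in this assay. It differs from compound 3 by methoxy in place of hydrogen on an aromatic carbon, the same change as that from compound 2 to compound 1, at a place described in the same words. Resting on compound 3 at 82800 nM and on the small measured step of an at least 1.0-fold lower number from compound 2 to compound 1 (0.02 log units; that floor lies within the scatter), the expected step is a 1.1-fold lower number from compound 3 to compound 4 (0.04 log units; within the scatter). Compound 4 is therefore estimated at 75000 nM, with a likely range from 30000 nM to 150000 nM.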

Compound 4, concentration for total growth inhibition: 85100 nM
The estimate for compound 4 lay 1.1-fold (0.05 log units) below the measured number; measured number inside the range.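

In this assay, methoxy on the core of compound 3 leaves the number essentially unmoved, with a 1.0-fold higher number from compound 3 to compound 4 (0.01 log units; within the scatter), and the group of one carbon and one sulfur in place of selenium is equally small, with a 1.1-fold lower number from compound 1 to compound 4 (0.04 log units; within the scatter). For the methoxy change, this shows only that the step is small where it can be read in full, on the core of compound 3; it does not show that the step is the same on both cores: the same change on two cores in this assay, an at least 1.0-fold lower number (0.02 log units; that floor lies within the scatter) from compound 2 to compound 1 and a 1.0-fold higher number (0.01 log units; within the scatter) from compound 3 to compound 4; the limit leaves it open whether they differ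

The exchange of selenium for the carbon and sulfur group likewise gives a small step where it can be read in full, but a match between the two cores remains unproven: the same change on two cores in this assay, an at least 1.2-fold lower number (0.08 log units; that floor lies within the scatter) from compound 2 to compound 3 and a 1.1-fold lower number (0.04 log units; within the scatter) from compound 1 to compound 4; the limit leaves it open whether they differ

The compounds shown leave open whether another group at the place para to a large group, such as an amine or a carboxylic acid, would shift the number beyond the scatter. Going by these compounds, it is also open whether a longer chain on the sulfur would do so.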